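Methoxy Shift on the Sulfonyl Aryl and Cytotoxicity

The source may report more compounds than this note shows. Statements on the series, on what has been measured and on what is new or still open speak of the compounds shown alone.

Working notes on three measured sulfonamides and one still to come. Compound 1 `COc1ccc(S(=O)(=O)Nc2ccc(-c3nc4ccccc4o3)cc2)cc1` was read in an ADME assay on HEK293 cells (Homo sapiens) for cytotoxicity, read by resazurin assay, with a stated time of 48 h; a lower number here means that less compound is tolerated, a higher number that more compound is tolerated. For compound 1 the result is a limit of the assay, > 100000 nM, so only a bound is known; it sits at the limit of > 100000 nM in this assay, at which 1 of the 3 values shown sits. Compound 2 `O=S(=O)(Nc1ccc2oc(-c3ccccc3)nc2c1)c1cccs1` gives 97000 nM in this assay, and compound 3 `O=S(=O)(Nc1ccc(-c2nc3ccccc3o2)cc1)c1ccc(Cl)c(C(F)(F)F)c1` gives 69000 nM; these two values lie within the usual scatter of each other. Going by the values given here, no step between measured compounds is available. Compound 4 `COc1ccccc1S(=O)(=O)Nc1ccc(-c2nc3ccccc3o2)cc1` differs from compound 1 by 2-methoxyphenyl in place of 4-methoxyphenyl on a sulfonyl sulfur. With the same atoms joined differently, and with compound 2 and compound 3 also reading high, no step beyond the scatter is expected; a number no higher from compound 1 to compound 4 (the limit leaves the size open) is the estimated step. Compound 4 is expected to give about 100000 nM in this assay, within 50000 nM to 200000 nM, quite possibly again as a limit.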

Compound 4, half-maximal cytotoxic concentration: > 100000 nM
Compound 4: only a limit was reported (the forecaster's own chance of this, stated with the estimate: 60%); the middle value sits exactly at the limit.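

Compound 1 and compound 4 both stand at a limit of the assay, so no step between them can be read: the limit of > 100000 nM in this assay, at which 2 of the 4 values shown sit.

The compounds shown leave open whether 2-methoxyphenyl in place of 4-methoxyphenyl changes the reading in this assay at all.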